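Amide side-chain variation: bromo replaced by methyl

The source may report more compounds than this note shows. Statements on the series, on what has been measured and on what is new or still open speak of the compounds shown alone.

Measured so far:
compound 1, `COc1ccc(CN(C(=O)C=C(C)C)c2cc(OC)c(OC)c(OC)c2)cc1O`: 320 nM
compound 2, `COc1ccc(CN(C(=O)CN=[N+]=[N-])c2cc(OC)c(OC)c(OC)c2)cc1O`: 120 nM
compound 3, `COc1ccc(CN(C(=O)C(C)Br)c2cc(OC)c(OC)c(OC)c2)cc1O`: 120 nM

In a functional assay on MGC-803 cells (Homo sapiens) for inhibition, read by MTT assay, with a stated time of 48 h (a higher number here means a weaker inhibitor, a lower number a stronger inhibitor), compound 3 gives 120 nM. It stands level with compound 2, no change at the digits printed from compound 2 to compound 3 (within the scatter), and these two together hold the lowest numbers of the three. Compound 1 sits furthest away: a 2.7-fold lower number from compound 1 to compound 3 (0.43 log units; beyond the scatter), and in the same way a 2.7-fold lower number from compound 1 to compound 2 (0.43 log units; beyond the scatter). Compound 4, `COc1ccc(CN(C(=O)C(C)C)c2cc(OC)c(OC)c(OC)c2)cc1O`, is not yet measured. Its difference from compound 3: methyl in place of bromo on a saturated chain carbon bound to a carbonyl carbon and a saturated chain carbon.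

Within the data shown here, no measured step exchanges bromo for methyl. The two steps that reach compound 2 and compound 3 both start from the 2-methylprop-1-en-1-yl group of compound 1 and do not speak to this exchange. The only related observation is that compound 2 and compound 3 carry different small groups on the carbonyl carbon yet give the same number. Lacking a matched step, the expected step in this assay is a modest rise, a 3.3-fold higher number from compound 3 to compound 4 (0.52 log units; beyond the scatter), with a wide range. The estimate for compound 4 is 400 nM, between 120 nM and 1500 nM.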

Compound 4, half-maximal inhibitory concentration: 210 nM
Estimate against measurement, compound 4: 1.9-fold (0.28 log units) above; the measured number falls inside the stated range.
By their numbers in this assay, from the lowest: compounds 2, 3, 4 and 1 (each within the scatter of the next, the first and the last beyond it).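

In this assay, methyl in place of bromo on a saturated chain carbon bound to a carbonyl carbon and a saturated chain carbon gives a step within the scatter (a 1.8-fold higher number from compound 3 to compound 4 (0.24 log units; within the scatter)), so this position does not depend on the bromo to keep a number of this size. Isopropyl also stays within the scatter of azidomethyl (a 1.8-fold higher number from compound 2 to compound 4 (0.24 log units; within the scatter)) and of 2-methylprop-1-en-1-yl (a 1.5-fold lower number from compound 1 to compound 4 (0.18 log units; within the scatter)), which places compound 4 within reach of both ends of a set whose two ends still differ beyond the scatter (a 2.7-fold lower number from compound 1 to compound 2 (0.43 log units; beyond the scatter)). Nothing shown gives a reason for these readings.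

Still open, going by these compounds, is whether an amine or a carboxylic acid at this saturated chain carbon would give a step beyond the scatter from compound 3. The same question stands for a longer chain on the carbonyl carbon.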